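A Fluorophenyl Amine on the Shared Core

A few compounds are considered here, and "the series" means these few. Any claim that something is new, unique, unknown or untested is made for them only; others in the source may bear on it.

Among the measured compounds shown here, the three compounds measured so far share one core and differ only in the group on the amine nitrogen. Compound 1 `O=C1C=C(NCc2ccccc2)C(=O)c2c1nc1n2[C@H]2OC[C@@H](O)[C@H]2OC1` carries a benzyl group there; in a functional assay on HeLa cells (Homo sapiens) for inhibition, read by sulforhodamine B assay (a lower number here means a stronger inhibitor, a higher number a weaker inhibitor), compound 1 gives > 8000 nM, which is a limit of the assay and not a number. Compound 2 `O=C1C=C(NC2CCCCC2)C(=O)c2c1nc1n2[C@H]2OC[C@@H](O)[C@H]2OC1` carries a cyclohexyl group; in this assay compound 2 gives > 16000 nM, again a limit. For the measured compounds named here, compound 3 `CCOc1ccccc1NC1=CC(=O)c2nc3n(c2C1=O)[C@H]1OC[C@@H](O)[C@H]1OC3` carries a 2-ethoxyphenyl group, and in this assay compound 3 gives 6040 nM, the only number among the three. The step of an at least 1.3-fold lower number from compound 1 to compound 3 (0.12 log units; that floor lies within the scatter) has a floor within the scatter, whereas an at least 2.6-fold lower number from compound 2 to compound 3 (0.42 log units; beyond the scatter) reaches beyond it; the step that the two limits leave unreadable from compound 1 to compound 2 cannot be read, as the limit of > 16000 nM in this assay, at which 1 of the 3 values shown sits, and the limit of > 8000 nM in this assay, at which 1 of the 3 values shown sits, show.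

Compound 4 `O=C1C=C(Nc2cccc(F)c2)C(=O)c2c1nc1n2[C@H]2OC[C@@H](O)[C@H]2OC1` keeps the core and changes the amine substituent: 3-fluorophenyl in place of 2-ethoxyphenyl on an amine nitrogen. Neither measured step replaces one six-membered aromatic ring of carbon only with another, so no direct guide exists; the two steps ending at compound 3 only show that bringing in such a ring gave lower numbers than benzyl or cyclohexyl. Because compound 3 gives 6040 nM with such a ring, and compound 4 retains a ring of that kind, the expected step of a 1.3-fold higher number from compound 3 to compound 4 (0.12 log units; within the scatter) is small, with a modest rise in the number held likeliest. The estimate for compound 4 in this assay is 8000 nM, ranging from 2500 nM to 25000 nM.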

Compound 4, half-maximal inhibitory concentration: 6440 nM
Beside the measured number, compound 4's estimate is 1.2-fold (0.09 log units) above it; low and high end bracket the measured number.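

With one six-membered aromatic ring of carbon only replacing another on the amine nitrogen, the step is a 1.1-fold higher number from compound 3 to compound 4 (0.03 log units; within the scatter), so this assay does not tell the 2-ethoxyphenyl and 3-fluorophenyl groups apart, even though the ethoxy oxygen and its carbons leave and a fluorine enters. Against cyclohexyl, the step is an at least 2.4-fold lower number from compound 2 to compound 4 (0.39 log units; beyond the scatter), so compound 4 is a second compound with such a ring to reach beyond the scatter from compound 2, and this step is only a floor resting on a limit of the assay: the limit of > 16000 nM in this assay, at which 1 of the 4 values shown sits. Against benzyl, the step is an at least 1.2-fold lower number from compound 1 to compound 4 (0.09 log units; that floor lies within the scatter), which leaves compound 4 no more clearly separated from compound 1 than compound 3 was, and this floor also rests on a limit of the assay: the limit of > 8000 nM in this assay, at which 1 of the 4 values shown sits.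

The compounds shown leave open whether the number would hold with a plain phenyl group, a pyridine ring or a phenyl ring carrying a carboxylic acid or an amine. They also leave open the true size of the steps from the benzyl and cyclohexyl compounds.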